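The compounds below may be only part of what the source reports. "The series", "measured", "known", "first", "only" and "open" are said of these compounds alone.

Measured compounds:
- compound 1 `OC(CCCN1CCN(c2ncc(F)cn2)CC1)C1CCCCC1`, an assay (Cavia porcellus) for displacement of a labelled ligand from Sigma non-opioid intracellular receptor 1 (Homo sapiens); a higher number here means a weaker inhibitor, a lower number a stronger inhibitor: 12 nM
- compound 2 `OC(CCCN1CCN(c2ncc(F)cn2)CC1)(c1ccc(F)cc1)C1CCCCC1`, this assay: no result reported

Within the data shown here, compound 1 carries the only number; in this assay compound 1 gives 12 nM, so it is the sole reference point, and compound 2 adds nothing measurable to compare against it. Among the measured compounds shown here, no step between two measured compounds exists, so the size of any change has to be judged from the structures alone.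

Compound 3 `NC(CCCN1CCN(c2ncc(F)cn2)CC1)C1CCCCC1` is the next entry to be measured. It differs from compound 1 in one place: amino in place of hydroxy on a saturated chain carbon bound to a saturated chain carbon and a saturated ring carbon. The groups that leave and enter are of the same size and count of donors and acceptors, so the change is small on paper.

Without a measured pair of this kind in the series, the expectation for this assay is a step no larger than the usual scatter, with no firm direction; a modest shift either way would not be surprising. Compound 3 is expected to land near compound 1, the step from compound 1 to compound 3 estimated as no change at the digits printed from compound 1 to compound 3 (within the scatter). The estimate for compound 3 in this assay is 12 nM, within a range of 3 nM to 45 nM.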

Compound 3, half-maximal inhibitory concentration: 52 nM
Compound 3: the middle estimate sits 4.3-fold (0.64 log units) below what was measured, and the stated range ends below it.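

Read in this assay the exchange of amino for hydroxy on a saturated chain carbon bound to a saturated chain carbon and a saturated ring carbon gives a 4.3-fold higher number from compound 1 to compound 3 (0.64 log units; beyond the scatter) as the first readable step in the series. This position therefore responds to the identity of the group it carries, even though the leaving and entering groups match in heavy atoms, hydrogen-bond donors, hydrogen-bond acceptors and net charge as counted, so these counts alone do not settle the value here. The step rests on one pair, and no measurement on hand bears on why the number moved.

Going by these compounds, whether the step is particular to amino or would recur with a methoxy or dimethylamino group on the same carbon remains open. Also open, on these data alone, is whether the exchange of hydroxy for amino would give a step of similar size on a longer chain, since a single pair cannot show how far this result carries beyond the core of compound 1.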